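A few compounds are considered here, and "the series" means these few. Any claim that something is new, unique, unknown or untested is made for them only; others in the source may bear on it.

Compound 1 `COc1ccc(F)cc1CNCCCNc1ccnc2cc(Cc3ccc(F)cc3)ccc12` and compound 2 `COc1ccc(F)cc1CNCCCNc1ccnc2cc(Cc3cc(C)cc(C)c3)ccc12` share the same chain and the same shared core; they differ only in the ring carried on a saturated chain carbon bound to an aromatic carbon. In a physicochemical assay for solubility, with a stated time of 18 h, at pH 7.4 (a higher number here means a more soluble compound, a lower number a less soluble compound), compound 1 gives 4200 nM, and compound 2 gives 4200 nM. The step of no change at the digits printed from compound 1 to compound 2 (within the scatter) shows that exchanging one six-membered aromatic ring for another at that position left the solubility where it was, so compound 2 stands level with compound 1.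

Compound 3 `COc1ccc(F)cc1CNCCCNc1ccnc2cc(-c3cccc4ccccc34)ccc12` has not yet been measured. It differs from compound 2 in that naphthalen-1-yl in place of 3,5-dimethylbenzyl on an aromatic carbon: the saturated chain carbon is gone and the naphthalen-1-yl is bound directly to the shared core. Within the data shown here, the only measured step, no change at the digits printed from compound 1 to compound 2 (within the scatter), kept that saturated carbon and was flat, so it bears only loosely on this change; nothing measured shows what removing the saturated carbon or adding naphthalen-1-yl does. The expected step is therefore a 1.4-fold lower number from compound 2 to compound 3 (0.15 log units; within the scatter), small, probably within the scatter, and if anything downward. Compound 3 is estimated at 3000 nM, with a range from 1000 nM to 9000 nM.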

Compound 3, solubility: 32000 nM
Beside the measured number, compound 3's estimate is 11-fold (1.03 log units) below it, and the stated range ends below it.
By their numbers in this assay, from the lowest: compounds 1 and 2 (each within the scatter of the next); then compound 3.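

The position is not indifferent to what it carries. Exchanging one benzyl-type group for another changed nothing, with no change at the digits printed from compound 1 to compound 2 (within the scatter) in this assay, yet naphthalen-1-yl in place of 3,5-dimethylbenzyl on an aromatic carbon gives a 7.6-fold higher number from compound 2 to compound 3 (0.88 log units; beyond the scatter), and naphthalen-1-yl in place of 4-fluorobenzyl gives a 7.6-fold higher number from compound 1 to compound 3 (0.88 log units; beyond the scatter). Both of these changes remove the saturated chain carbon and bring in a second six-membered aromatic ring at once, so the two benzyl-type groups reach the same higher reading by one combined change, and no measurement here explains the rise.

The compounds shown leave open which part of that combined change carries the step: a phenyl bound directly to the shared core would test the loss of the saturated carbon alone, while a naphthalen-1-ylmethyl group would test the second ring with that carbon kept. They also leave open how a ring bearing an amine or a carboxylic acid would read at this position, and whether the step survives a longer chain between the two nitrogens.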